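Stability notes: from compound 3 to compound 4

A few compounds are considered here, and "the series" means these few. Any claim that something is new, unique, unknown or untested is made for them only; others in the source may bear on it.

Compound 3 (`C[C@]1(C(=O)N2CC[C@](c3ccc(C(F)(C(F)(F)F)C(F)(F)F)cc3)(S(=O)(=O)c3ccc(F)cc3)C2)CC[C@@H](C(=O)O)CC1`), compound 2 (`CO[C@]1(C(=O)N2CC[C@](c3ccc(C(F)(C(F)(F)F)C(F)(F)F)cc3)(S(=O)(=O)c3ccc(F)cc3)C2)CC[C@H](C(=O)O)CC1`) and compound 1 (`CC[C@]1(C(=O)O)CC[C@H](C(=O)N2CC[C@](c3ccc(C(F)(C(F)(F)F)C(F)(F)F)cc3)(S(=O)(=O)c3ccc(F)cc3)C2)CC1`) differ in the group on the carbonyl carbon of the amide. In an ADME assay on microsomes from liver (Mus musculus) for metabolic stability, with a stated time of 10 min (a higher number here means that more of the compound is left, a lower number that less of the compound is left), compound 3 gives 100% and stands level, within the scatter, with compound 2 at 95% in the same test. For compound 1 the entry is "not determined" (no result reported) and offers no number for comparison.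

Compound 4 (`O=C(O)C12CCC(C(=O)N3CC[C@](c4ccc(C(F)(C(F)(F)F)C(F)(F)F)cc4)(S(=O)(=O)c4ccc(F)cc4)C3)(CC1)CC2`) carries a new group at that place: a group of 11 heavy atoms (9 carbon, 2 oxygen; 2 six-membered non-aromatic rings of carbon only) in place of a group of 10 heavy atoms (8 carbon, 2 oxygen; one six-membered non-aromatic ring of carbon only), on a carbonyl carbon. Within the data shown here, the entering group has no common name and no counterpart among the measured compounds.

Among the measured compounds shown here, one measured step bears on this change, namely a number 5 percentage points higher from compound 2 to compound 3 (within the scatter) at the same carbonyl carbon. It stays within the scatter, but it is thin evidence, since neither of its two groups has the second ring of compound 4. With compound 3 at 100% the read-out leaves room for movement in one direction only, so any shift is expected to be downward. The expected change is a number 5 percentage points lower from compound 3 to compound 4 (within the scatter) and is estimated to stay within the scatter, although a larger loss cannot be excluded. The estimate for compound 4 is 95%, with an expected range from 80% to 100% in this test.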

Compound 4, percent of the compound remaining: 73%
Estimate against measurement, compound 4: 22 percentage points above; measured number outside the range, below it.
By their numbers in this assay, from the lowest: compound 4; then compounds 2 and 3 (each within the scatter of the next).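

In this assay, the group on the carbonyl carbon proves able to shift the read-out: the entering group, with its 2 six-membered non-aromatic rings of carbon only, gives a number 27 percentage points lower from compound 3 to compound 4 (beyond the scatter) and also a number 22 percentage points lower from compound 2 to compound 4 (beyond the scatter). Among these compounds, the two single-ring groups, 4-carboxy-1-methylcyclohexyl and 4-carboxy-1-methoxycyclohexyl, had stayed level within the scatter, so these are the first steps at this place that lie beyond it, and both fall in the same direction. No measurement shown here offers a reason for the lower number.

Compound 1 gives "not determined" (no result reported), so its ethyl-bearing ring adds no third single-ring group against which to judge how far the read-out moves when only the group on that ring changes. Going by these compounds, it also remains open whether the lower number goes with the second ring itself, and whether a primary amide or a hydroxymethyl group in place of the carboxylic acid on the entering group would raise or lower it further.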